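The source may hold more compounds than are shown below. What is called first, only, known or untested is meant among the compounds shown, and "the series" means these compounds.

Compound 1 `CN1C/C(=C\c2c(F)cc(F)cc2F)C(=O)/C(=C/c2c(F)cc(F)cc2F)C1` opens the account. In a functional assay on PANC-1 cells (Homo sapiens) for cytotoxicity, read by MTT assay, with a stated time of 72 h (on this read-out higher numbers stand for weaker inhibition and lower numbers for stronger inhibition), compound 1 gives > 10000 nM, which is a limit of the assay and not a number. Going by the values given here, the only numbers nearby come from two relatives, compound 2 `CCN1C/C(=C\c2cc(F)cc(F)c2)C(=O)/C(=C/c2cc(F)cc(F)c2)C1` and compound 3 `CCN1C/C(=C\c2cc(F)c(F)cc2F)C(=O)/C(=C/c2cc(F)c(F)cc2F)C1`. Both carry an ethyl group where compound 1 has a methyl, but their fluorine patterns differ from that of compound 1, so neither gives a direct comparison with it.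

Compound 4 `CCN1C/C(=C\c2c(F)cc(F)cc2F)C(=O)/C(=C/c2c(F)cc(F)cc2F)C1` keeps the fluorine pattern of compound 1 and alters one place: methyl in place of hydrogen on a saturated chain carbon bound to an amine nitrogen in a ring. This is methyl in place of hydrogen on a saturated chain carbon bound to an amine nitrogen in a ring, so that methyl becomes ethyl.

A step toward stronger inhibition is expected in this assay, of moderate to large size. That expectation rests on compound 2 at 1100 nM and compound 3 at 830 nM, two ethyl compounds whose values lie within the usual scatter of each other. The estimated step is an at least 4.0-fold lower number from compound 1 to compound 4 (0.60 log units; beyond the scatter), and it remains loose, as its starting point is only a limit. For compound 4 the expected value is 2500 nM, with an estimated range from 600 nM to 10000 nM.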

Compound 4, half-maximal inhibitory concentration: 1300 nM
For compound 4 the middle estimate is 1.9-fold (0.28 log units) above the measured one; the measured number falls inside the stated range.
By their numbers in this assay, from the lowest: compounds 3, 2 and 4 (each within the scatter of the next). At a limit, above all of these: compound 1.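

Going by these compounds alone, with the fluorine pattern held fixed, compound 4 gives the first pair in which this change can be read on its own: in this assay, methyl in place of hydrogen on a saturated chain carbon bound to an amine nitrogen in a ring goes with an at least 7.6-fold lower number from compound 1 to compound 4 (0.88 log units; beyond the scatter). Within the data shown here, compound 2 and compound 3 could not show this, as each differs from compound 1 in its fluorine pattern as well as in the ethyl group, so the link between this place and a lower number now rests on a direct comparison for the first time. The size of the step remains only a bound, because one end of it is a limit of the assay and not a number: the limit of > 10000 nM in this assay, at which 1 of the 4 values shown sits.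

The compounds shown leave open whether a longer chain, such as propyl, or a benzyl group at this place would continue the step, hold it or reverse it. They also leave open whether the same change from methyl to ethyl would give a step of similar size on the fluorine patterns of compound 2 and compound 3.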